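Swapping the Piperazine Substituent: From Oxetane to Fused Bicycle

The compounds below may be only part of what the source reports. "The series", "measured", "known", "first", "only" and "open" are said of these compounds alone.

Measured so far:
- Compound 1 `CN(C[C@H]1Cc2c(cccc2N2CCN(C3COC3)CC2)CN1)[C@H]1CCCc2cccnc21`: 381 nM
- Compound 2 `CN(C[C@H]1Cc2c(cccc2N2CCN(c3ncccn3)CC2)CN1)[C@H]1CCCc2cccnc21`: 30.7 nM

Among the measured compounds shown here, in a functional assay on CCRF-CEM cells for antagonist activity at C-X-C chemokine receptor type 4 (Homo sapiens), read by calcium flux, with stated times of 25 min and 90 s (on this read-out lower numbers stand for stronger inhibition and higher numbers for weaker inhibition), compound 1 gives the highest of the two numbers; the only neighbour is compound 2, reached by a 12-fold lower number from compound 1 to compound 2 (1.09 log units; beyond the scatter) through pyrimidin-2-yl in place of oxetan-3-yl on an amine nitrogen in a ring.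

Compound 3 `CN(C[C@H]1Cc2c(cccc2N2CCN3CCC[C@H]3C2)CN1)[C@H]1CCCc2cccnc21` is not yet measured. It differs from compound 1 by a group of 9 heavy atoms (7 carbon, 2 nitrogen; one five-membered non-aromatic ring with 1 hetero atom, one six-membered non-aromatic ring with 2 hetero atoms) in place of a group of 10 heavy atoms (7 carbon, 2 nitrogen, 1 oxygen; one four-membered non-aromatic ring with 1 hetero atom, one six-membered non-aromatic ring with 2 hetero atoms), on an aromatic carbon. For the measured compounds named here, only one measured step exists, and it changes the same part of the molecule, but with a different group entering, so it offers a hint rather than a rule: a change at this position can shift the number a great deal. For compound 3 a step of a 1.9-fold lower number from compound 1 to compound 3 (0.28 log units; within the scatter) is expected, smaller than the measured one and with wide uncertainty. Compound 3 is therefore expected to give about 200 nM in this assay, within a range of 60 nM to 700 nM.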

Compound 3, half-maximal inhibitory concentration: 2.92 nM
Estimate against measurement, compound 3: 68-fold (1.84 log units) above; the whole stated range lies above it.
By their numbers in this assay, from the lowest: compound 3; then compound 2; then compound 1.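

In this assay the large step of a 130-fold lower number from compound 1 to compound 3 (2.12 log units; beyond the scatter) shows that this aromatic carbon can carry a group of two fused non-aromatic rings, with no oxetan-3-yl group, and give a far lower number. An aromatic ring such as pyrimidin-2-yl is therefore not required for a large gain at this position: compound 2 gives 30.7 nM and compound 3 gives 2.92 nM in the same read-out. Nothing measured here offers a reason for this gain.

Still open, as far as these compounds go, is whether the gain rests on the five-membered ring or simply on losing the oxetan-3-yl group, a question that a piperazine carrying a plain methyl group on its nitrogen would help to separate. Also open, from the compounds shown here alone, is how the opposite configuration at the defined stereocentre of the entering group would read.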